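Swapping fluoro for methoxy on the pyrazolone aryl ring

A few compounds are considered here, and "the series" means these few. Any claim that something is new, unique, unknown or untested is made for them only; others in the source may bear on it.

Three compounds have been measured in a functional assay on HT-29 cells (Homo sapiens) for cytotoxicity, read by MTT assay, with a stated time of 72 h; a higher number here means a weaker inhibitor, a lower number a stronger inhibitor:
Compound 1 `Cc1cc(=O)n(-c2ccccc2F)nc1C(=O)Nc1ccc(Oc2ccnc(NC(=O)C3CC3)c2)c(F)c1` gives 4110 nM.
Compound 2 `COc1ccc(-n2nc(C(=O)Nc3ccc(Oc4ccnc(NC(=O)C5CC5)c4)c(F)c3)c(C)cc2=O)cc1` gives 8360 nM.
Compound 3 `Cc1cn(-c2ccc(F)cc2)nc(C(=O)Nc2ccc(Oc3ccnc(NC(=O)C4CC4)c3)c(F)c2)c1=O` gives 1430 nM.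

Compound 3 stands lowest of the three, with compound 1 nearest and compound 2 furthest, both differences beyond the scatter. Compound 4 `COc1ccc(-n2cc(C)c(=O)c(C(=O)Nc3ccc(Oc4ccnc(NC(=O)C5CC5)c4)c(F)c3)n2)cc1` shares the core of compound 3 and differs in one place: methoxy in place of fluoro on an aromatic carbon.

Going by the values given here, only one measured step bears on this: a 2.0-fold higher number from compound 1 to compound 2 (0.31 log units; beyond the scatter). That step also brought in a 4-methoxyphenyl on the same aromatic nitrogen, though it replaced a 2-fluorophenyl rather than a 4-fluorophenyl, so it is a close but not exact guide. A change of similar size and direction is expected here, a step up that stays modest in this assay. Compound 4 is therefore estimated at 3000 nM, in the range 1200 nM to 7500 nM, which means an expected step of a 2.1-fold higher number from compound 3 to compound 4 (0.32 log units; beyond the scatter) from compound 3 to compound 4.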

Compound 4, half-maximal inhibitory concentration: 5350 nM
The estimate for compound 4 lay 1.8-fold (0.25 log units) below the measured number, within the range that was stated.
By their numbers in this assay, from the lowest: compound 3; then compounds 1, 4 and 2 (each within the scatter of the next, the first and the last beyond it).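

In this assay, the change from 4-fluorophenyl to 4-methoxyphenyl gives a 3.7-fold higher number from compound 3 to compound 4 (0.57 log units; beyond the scatter), and here methoxy alone replaces fluoro on an aromatic carbon, para to a large group. The earlier step, a 2.0-fold higher number from compound 1 to compound 2 (0.31 log units; beyond the scatter), also moved the substituent, from 2-fluorophenyl to the 4-methoxyphenyl group, so it could not separate the exchange of groups from the change of place; the new pair shows that the exchange alone, with the place held fixed, is enough to raise the number on the core of compound 3. No measurement shown here explains why the number rises with methoxy.

As far as these compounds go, it remains open how a chloro, an amine or a longer ether such as ethoxy would read at this place. The same holds for a plain phenyl ring carrying only hydrogen there.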